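Iodo in place of methyl on compound 3

The source may report more compounds than this note shows. Statements on the series, on what has been measured and on what is new or still open speak of the compounds shown alone.

In a functional assay on MCF7 cells (Homo sapiens) for inhibition (on this read-out higher numbers stand for weaker inhibition and lower numbers for stronger inhibition), compound 1 (`Oc1ccc(-c2nc3ccc(Cl)cc3s2)cc1`) gives 26500 nM and compound 2 (`COc1cccc(-c2nc3cc(F)ccc3o2)c1`) gives 39500 nM while compound 3 (`COc1ccc(-c2nc3cc(F)ccc3s2)cc1C`) gives 48 nM as the lowest of the three numbers, with its gaps to both others beyond the scatter. Compound 4 (`COc1ccc(-c2nc3cc(F)ccc3s2)cc1I`) carries iodo in place of methyl on an aromatic carbon, ortho to a methoxy group and meta to a large group (iodo in place of methyl on an aromatic carbon). For the measured compounds named here, no two measured compounds differ in one place, so no direct step informs this exchange. A modest move toward weaker inhibition is expected, with an estimated 2.5-fold higher number from compound 3 to compound 4 (0.40 log units; beyond the scatter) as the likely size. Compound 4 is expected at 120 nM (estimated range 20 nM to 900 nM).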

Compound 4, half-maximal inhibitory concentration: 820 nM
Beside the measured number, compound 4's estimate is 6.8-fold (0.83 log units) below it; the measured number falls inside the stated range.
By their numbers in this assay, from the lowest: compound 3; then compound 4; then compounds 1 and 2 (each within the scatter of the next).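

In this assay, iodo in place of methyl on this aromatic carbon, ortho to a methoxy group, gives a 17-fold higher number from compound 3 to compound 4 (1.23 log units; beyond the scatter) and so marks this position as sensitive to the exchange, with methyl giving the stronger inhibition of the two. The exchange swaps one heavy atom for one, with no hydrogen-bond donor, acceptor or net charge entering or leaving, so these counts do not separate compound 3 from compound 4. No measurement at hand accounts for the step. Going by these compounds, whether chloro, ethyl or an amine on this carbon would sit nearer compound 3 or compound 4 stays open. On these data alone, whether the same exchange gives a step of similar size with a hydroxyl in place of the methoxy group also stays open.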